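The source may report more compounds than this note shows. Statements on the series, on what has been measured and on what is new or still open speak of the compounds shown alone.

Series notes. The shared core is carried by compound 1 `Cc1ccc(S/C(=C/c2c[nH]c3ccccc23)C(=O)c2ccc(Br)cc2)cc1`, compound 2 `Cc1ccc(S/C(=C/c2ccc(Cl)c(Cl)c2)C(=O)c2ccc(Br)cc2)cc1`, compound 3 `Cc1ccc(S/C(=C/c2ccc(C)s2)C(=O)c2ccc(Br)cc2)cc1` and the not yet measured compound 4 `COc1ccccc1/C=C(/Sc1ccc(C)cc1)C(=O)c1ccc(Br)cc1`. In a functional assay on DU-145 cells (Homo sapiens) for inhibition, read by trypan blue exclusion, with a stated time of 96 h (a higher number here means a weaker inhibitor of growth, a lower number a stronger inhibitor of growth), compound 1 gives 10000 nM and compound 2 gives 50000 nM. Compound 3 reaches only a limit of this assay, > 100000 nM. That ceiling is the one noted in the limit of > 100000 nM in this assay, at which 1 of the 3 values shown sits. The measured steps are a 5.0-fold higher number from compound 1 to compound 2 (0.70 log units; beyond the scatter), an at least 10-fold higher number from compound 1 to compound 3 (1.00 log units; beyond the scatter) and an at least 2.0-fold higher number from compound 2 to compound 3 (0.30 log units; that floor lies within the scatter). Compound 4 differs from compound 3 by 2-methoxyphenyl in place of 5-methylthiophen-2-yl on a double-bonded chain carbon bound to a double-bonded chain carbon. The step of an at least 2.0-fold higher number from compound 2 to compound 3 (0.30 log units; that floor lies within the scatter) bears most directly on this change, a six-membered aromatic ring of carbon only re-entering. A downward step is expected, about an at least 2.0-fold lower number from compound 3 to compound 4 (0.30 log units; that floor lies within the scatter). Compound 4 is accordingly estimated at 50000 nM, within 20000 nM to 120000 nM, with a fair chance that only a limit is again recorded.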

Compound 4, concentration for 50% growth inhibition: 9000 nM
Compound 4: middle estimate off by 5.6-fold (0.74 log units), on the high side; the measured number lies below the stated range.
By their numbers in this assay, from the lowest: compounds 4 and 1 (each within the scatter of the next); then compound 2. At a limit, above all of these: compound 3.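

In this assay, 2-methoxyphenyl at this place brings a six-membered aromatic ring of carbon only level with 1H-indol-3-yl (a 1.1-fold lower number from compound 1 to compound 4 (0.05 log units; within the scatter)), so among these compounds the indole is not required. Ring type alone does not set the number: 3,4-dichlorophenyl and 2-methoxyphenyl, both carbon-only rings, stand apart (a 5.6-fold lower number from compound 2 to compound 4 (0.74 log units; beyond the scatter)). The step from 5-methylthiophen-2-yl (an at least 11-fold lower number from compound 3 to compound 4 (1.04 log units; beyond the scatter)) is only a floor, with compound 3 standing at a limit: the limit of > 100000 nM in this assay, at which 1 of the 4 values shown sits.

Open, from the compounds shown here alone, is whether the methoxy group itself carries the difference from 3,4-dichlorophenyl. Also open, going by these compounds, is how a phenyl ring bearing an amine or a carboxylic acid would read at this place.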